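Ether in place of thioether on a difluorinated aryl core

The source may report more compounds than this note shows. Statements on the series, on what has been measured and on what is new or still open speak of the compounds shown alone.

Measured compounds:
compound 1, `CC(C)Nc1ccccc1-c1cc(F)c(OCCCC(=O)O)c(F)c1`, > 100000 nM
compound 2, `CO[C@H]1C[C@H](Oc2cc(F)c(F)c(-c3cc(C)c(OCCCC(=O)O)c(C)c3)c2)C1`, > 100000 nM
compound 3, `CO[C@H]1C[C@H](Oc2cc(F)c(F)c(-c3cc(F)c(SCCCC(=O)O)c(F)c3)c2)C1`, > 100000 nM

Compound 3 has the structure `CO[C@H]1C[C@H](Oc2cc(F)c(F)c(-c3cc(F)c(SCCCC(=O)O)c(F)c3)c2)C1`. In a functional assay on CHO cells for agonist activity at Free fatty acid receptor 1 (Homo sapiens), read by calcium flux (on this read-out lower numbers stand for an effect already at smaller amounts and higher numbers for an effect only at larger amounts of compound), compound 3 gives only a limit, > 100000 nM, and not a number. Compound 1 gives in this assay likewise only a limit, > 100000 nM. Compound 2 also reaches only a limit in this assay, > 100000 nM. Among the measured compounds shown here, all three measured values thus sit at the same point, (the limit of > 100000 nM in this assay, at which 3 of the 3 values shown sit), and there is no step between measured compounds that can be stated in this assay.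

Compound 4, `CO[C@H]1C[C@H](Oc2cc(F)c(F)c(-c3cc(F)c(OCCCCC(=O)O)c(F)c3)c2)C1`, has not yet been measured. It differs from compound 3 in one place: 4-carboxybutoxy in place of (3-carboxypropyl)sulfanyl on an aromatic carbon.

With every measured value at the limit, nothing quantifies what this change does, and no direction can be read from the data. Compound 4 is expected to remain at the limit, so that the step of a number no higher from compound 3 to compound 4 (the limit leaves the size open) is estimated to be none beyond the scatter. For compound 4 the estimate in this assay is 100000 nM, with a range from 3000 nM to 300000 nM.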

Compound 4, half-maximal effective concentration: 68800 nM
Estimate against measurement, compound 4: 1.5-fold (0.16 log units) above, within the range that was stated.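

In this assay compound 4 gives 68800 nM, the first actual number among the compounds shown, so activity on this core can now be read as a value at all. On these data alone, putting 4-carboxybutoxy in place of (3-carboxypropyl)sulfanyl, on an aromatic carbon ortho to two fluoro groups and para to a large group, gives an at least 1.4-fold lower number from compound 3 to compound 4 (0.16 log units; that floor lies within the scatter); the starting value is a limit, so this is only a floor, and the true size of the step remains unknown. The position therefore tolerates a change that moves the result off the point where the other compounds sit: the limit of > 100000 nM in this assay, at which 3 of the 4 values shown sit.

The change alters the linking atom and the chain at once, and the compounds shown cannot separate the two, since (4-carboxybutyl)sulfanyl at this place would be needed to tell the exchange of sulfur for oxygen from the added chain length. They also leave open whether a still longer chain, such as 5-carboxypentoxy, would lower the number further, or whether the value of compound 4 marks the end of this trend.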